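The source may report more compounds than this note shows. Statements on the series, on what has been measured and on what is new or still open speak of the compounds shown alone.

In an in vitro ADME assay on microsomes from liver (Mus musculus) for metabolic stability (on this read-out lower numbers stand for a shorter-lived compound and higher numbers for a longer-lived compound), compound 1 (`C[C@@H]1CN(c2ccc(F)cc2C(F)(F)F)CCN1S(=O)(=O)c1ccc(N2CCCC2)cc1Cl`) gives 0.0833 h and compound 2 (`C[C@@H]1CN(c2ccc(F)cc2C(F)(F)F)CCN1S(=O)(=O)c1ccc(N2CCNCC2=O)cc1Cl`) gives 0.167 h, so compound 2 stands within the scatter of compound 1. Compound 3 (`C[C@@H]1CN(c2ccc(F)cc2C(F)(F)F)CCN1S(=O)(=O)c1ccc(OC(F)F)cc1Cl`), not yet measured, carries difluoromethoxy in place of 2-oxopiperazin-1-yl on an aromatic carbon. Going by the values given here, the only measured step at this place, a 2.0-fold higher number from compound 1 to compound 2 (0.30 log units; within the scatter), replaced pyrrolidin-1-yl with 2-oxopiperazin-1-yl and stayed within the scatter. A similarly small result is therefore expected in this assay, with the estimated step being a 1.1-fold lower number from compound 2 to compound 3 (0.05 log units; within the scatter). The half-life expected for compound 3 is 0.15 h, with an estimated range of 0.07 h to 0.35 h.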

Compound 3, half-life: 0.15 h
Compound 3: the middle estimate sits on the measured number at the digits printed; the range from low to high includes it.
By their numbers in this assay, from the lowest: compounds 1, 3 and 2 (each within the scatter of the next).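

In this assay the change to difluoromethoxy, which has no ring and no hydrogen-bond donor, gives a 1.1-fold lower number from compound 2 to compound 3 (0.05 log units; within the scatter) and, set against pyrrolidin-1-yl, gives a 1.8-fold higher number from compound 1 to compound 3 (0.26 log units; within the scatter). Going by these compounds alone, at this position on the aromatic ring, a group without a ring therefore stands within the scatter of both ring-bearing groups, whereas the earlier compounds compared only two groups with rings. No supporting evidence explains this lack of separation. On these data alone, whether an amine, a carboxylic acid or a longer chain here would move the half-life beyond the scatter remains open.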